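Swapping fluoro for chloro on a benzyl-bearing core

The source may hold more compounds than are shown below. What is called first, only, known or untested is meant among the compounds shown, and "the series" means these compounds.

Among the measured compounds shown here, compound 2 `Cc1cc(Nc2nc(NCc3ccccc3F)nc3[nH]ncc23)n[nH]1` is the stronger of the two compounds measured so far in an assay on isolated protein for inhibition of serine/threonine-protein kinase PAK 4 (Homo sapiens), read by HTRF, with a stated time of 60 min; a higher number here means a weaker inhibitor, a lower number a stronger inhibitor: in this assay compound 2 gives 389 nM. Its partner compound 1 `Cc1cc(Nc2nc(NC3CCNC3)nc3[nH]ncc23)n[nH]1` carries pyrrolidin-3-yl in place of the 2-fluorobenzyl group, and in this assay compound 1 gives 1050 nM. For the measured compounds named here, the only measured step, a 2.7-fold lower number from compound 1 to compound 2 (0.43 log units; beyond the scatter), concerns a different change, the group on a nitrogen on an aromatic ring, not the halogen. Compound 3 `Cc1cc(Nc2nc(NCc3ccccc3Cl)nc3[nH]ncc23)n[nH]1` keeps everything in compound 2 and differs in one place: chloro in place of fluoro on an aromatic carbon, on an aromatic carbon of a six-membered aromatic ring of carbon only, ortho to a large group. Going by the values given here, no measured step touches this halogen swap, so the numbers give no direction for it, and the expected step is a 1.1-fold lower number from compound 2 to compound 3 (0.05 log units; within the scatter), within the usual scatter. Compound 3 is accordingly estimated at 350 nM in this assay, with a likely range from 150 nM to 900 nM.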

Compound 3, half-maximal inhibitory concentration: 668 nM
For compound 3 the middle estimate is 1.9-fold (0.28 log units) below the measured one; the measured number falls inside the stated range.
By their numbers in this assay, from the lowest: compounds 2, 3 and 1 (each within the scatter of the next, the first and the last beyond it).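

At this position, ortho to a large group, chloro in place of fluoro gives a small step (a 1.7-fold higher number from compound 2 to compound 3 (0.23 log units; within the scatter)), so this assay does not separate these two halogens here. The halogen does affect how the comparison with pyrrolidin-3-yl reads: 2-fluorobenzyl gave a step beyond the scatter (a 2.7-fold lower number from compound 1 to compound 2 (0.43 log units; beyond the scatter)), whereas 2-chlorobenzyl gives one within it (a 1.6-fold lower number from compound 1 to compound 3 (0.20 log units; within the scatter)), so the gain seen with 2-fluorobenzyl does not clearly carry over to 2-chlorobenzyl. No independent measurement is available to explain these numbers.

The compounds shown leave open how an unsubstituted benzyl group, or bromo, methyl or methoxy at this same place, would read. They also leave open whether an amine on the ring would change the picture.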